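Methoxy addition on a second core: cytotoxicity outlook

The source may report more compounds than this note shows. Statements on the series, on what has been measured and on what is new or still open speak of the compounds shown alone.

Compound 1 `CC(=O)Nc1ccc(O)c(C(=O)/C=C/c2ccccc2)c1` gives 49400 nM in an ADME assay on MT4 cells (Homo sapiens) for cytotoxicity, read by MTT assay, with a stated time of 4 days; a lower number here means that less compound is tolerated, a higher number that more compound is tolerated. Compound 2 `COc1ccccc1/C=C/C(=O)c1cc(NC(C)=O)ccc1O` gives 37800 nM in this assay; the change is methoxy in place of hydrogen on an aromatic carbon, and the step is a 1.3-fold lower number from compound 1 to compound 2 (0.12 log units; within the scatter). Compound 3 `CC(=O)Nc1ccc2oc(-c3ccccc3)cc(=O)c2c1` gives 184000 nM in this assay, the highest of the three numbers, and its gap to compound 1 lies beyond the scatter; the difference between the two cores is not broken down here. Compound 4 `COc1cccc(-c2cc(=O)c3cc(NC(C)=O)ccc3o2)c1` is unmeasured; it differs from compound 3 by methoxy in place of hydrogen on an aromatic carbon. The place is not the same word for word: in compound 2 the methoxy sits ortho to a large group, in compound 4 meta to a large group, so this is the same kind of change, not the same. The expected step is a 1.2-fold lower number from compound 3 to compound 4 (0.09 log units; within the scatter), resting on the step of the same kind a 1.3-fold lower number from compound 1 to compound 2 (0.12 log units; within the scatter). Compound 4 is estimated at 150000 nM, between 70000 nM and 320000 nM.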

Compound 4, half-maximal cytotoxic concentration: > 404000 nM
Compound 4 ended at the assay's limit; the forecaster's own chance of this, stated with the estimate: 15%; middle value at least 2.6-fold (0.43 log units) away from the limit.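

On the second core, methoxy in place of hydrogen on an aromatic carbon gives an at least 2.1-fold higher number from compound 3 to compound 4 (0.34 log units; beyond the scatter) in this assay. The step does not carry over unchanged between the two cores: the same change on two cores in this assay, a 1.3-fold lower number (0.12 log units; within the scatter) from compound 1 to compound 2 and an at least 2.1-fold higher number (0.34 log units; beyond the scatter) from compound 3 to compound 4, at least 2.8-fold (0.45 log units) apart, beyond the scatter of two such steps. On these data alone, compound 4 stands at a limit of the assay, > 404000 nM, so the full size of its step is unknown, and the place of the methoxy is not the same in the two pairs, so these data do not separate the effect of the core from that of the place on the ring.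

As far as these compounds go, whether methoxy at one shared place gives matching steps on both cores remains open. Also open, from the compounds shown here alone, is how an amine or a carboxylic acid in place of the same hydrogen would read on either core.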